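Swapping a pyridinyl for a methylphenyl on a thiophene core

The source may hold more compounds than are shown below. What is called first, only, known or untested is meant among the compounds shown, and "the series" means these compounds.

Three compounds sharing one core were tested in an assay on CHO cells for displacement of a labelled ligand from adenosine receptor A3 (Homo sapiens), read by scintillation counting, tested at 10 uM; on this read-out higher numbers stand for more inhibition at the one concentration tested (going by the name of the read-out) and lower numbers for less inhibition. Compound 1 `Nc1sc(-c2ccccc2)c(-c2ccccc2)c1C(=O)c1ccc(Cl)cc1` gives 1%. Compound 2 `CC(C)(C)Cc1c(-c2ccncc2)sc(N)c1C(=O)c1ccc(Cl)cc1` gives 6% in this assay. Compound 3 `CC(C)(C)Cc1c(-c2ccc(OC(F)(F)F)cc2)sc(N)c1C(=O)c1ccc(Cl)cc1` gives 1%. The number for compound 2 differs from those of compound 1 and compound 3 by amounts that fall within the usual scatter of such measurements, so the three cannot be told apart on these data.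

Compound 4 `Cc1cccc(-c2sc(N)c(C(=O)c3ccc(Cl)cc3)c2CC(C)(C)C)c1` is not yet measured. Compared with compound 2, the change is 3-methylphenyl in place of pyridin-4-yl on an aromatic carbon. Going by the values given here, no step between measured compounds is on hand to guide the size of this change, and all three measured values sit close to one another, so no step beyond the scatter is expected in this assay. Compound 4 is estimated at 4% in this assay, within a range of 0% to 15%, and the expected step is a number 2 percentage points lower from compound 2 to compound 4 (within the scatter).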

Compound 4, a percentage reported as inhibition, at one concentration (the size of the read-out at that concentration, not a potency): 1%
Compound 4: middle estimate off by 3 percentage points, on the high side; the measured number falls inside the stated range.
By their numbers in this assay, from the lowest: compounds 1, 3, 4 and 2 (each within the scatter of the next).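

Going by these compounds alone, this is the first step that can be read at this position, the aromatic carbon next to the ring sulfur. In this assay, 3-methylphenyl in place of pyridin-4-yl gives a number 5 percentage points lower from compound 2 to compound 4 (within the scatter), so losing the ring nitrogen and gaining a methyl group leaves the two compounds indistinguishable. No measurement on hand offers an explanation for this result.

Still open, going by these compounds, is whether any group here can lift the number beyond the scatter, for example a carboxylic acid or an aminomethyl group on the phenyl ring.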